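Shortening the side chain of compound 1

The compounds below may be only part of what the source reports. "The series", "measured", "known", "first", "only" and "open" are said of these compounds alone.

In a physicochemical assay for lipophilicity (a higher number here means a more lipophilic compound, a lower number a more polar compound), compound 1 `COCc1cncc(C#Cc2ccccn2)c1` gives 2 and is the lower of the two measured compounds. Compound 2 `COCc1cncc(C#Cc2csc(C)n2)c1` gives 2.4 and the gap between them lies beyond the usual scatter. Compound 3 `COc1cncc(C#Cc2ccccn2)c1` has not been measured yet. Going by the values given here, it keeps the core of compound 1 but has methoxy in place of methoxymethyl on an aromatic carbon as its only change. Among the compounds with values here, no measured pair shows this swap, so any forecast is rough. In this assay a small rise is expected, with a number 0.30 log units higher from compound 1 to compound 3 (within the scatter) as the estimated step. Compound 3 is estimated at 2.3 (range 1.9 to 2.7).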

Compound 3, distribution coefficient: 2.25
Compound 3: the middle estimate sits 0.05 log units above what was measured; measured number inside the range.
By their numbers in this assay, from the lowest: compounds 1, 3 and 2 (each within the scatter of the next, the first and the last beyond it).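

In this assay, methoxy in place of methoxymethyl on this aromatic carbon gives a number 0.25 log units higher from compound 1 to compound 3 (within the scatter). Going by these compounds alone, this is the first measured pair for this position, and it shows that this swap leaves the two compounds indistinguishable in this measurement. Within the data shown here, nothing measured so far bears on the reason for this result.

Still open, on these data alone, is whether the same swap on the core of compound 2 would give a similar step. Also open, as far as these compounds go, is how an amine or a longer chain, such as ethoxyethyl, would read at this position in this assay.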